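Fluoro in place of methyl: expectation for compound 4

The compounds below may be only part of what the source reports. "The series", "measured", "known", "first", "only" and "open" are said of these compounds alone.

Compound 3 `Cc1ccc2c(c1)C1(C(=O)N2Cc2ccccc2)C(C#N)=C(N)Oc2cc3oc(-c4ccccc4)cc(=O)c3c(O)c21` stands at a limit of a functional assay on NCI-H1299 cells (Homo sapiens) for antiproliferative activity, read by MTT assay, with a stated time of 48 h (a higher number here means a weaker inhibitor, a lower number a stronger inhibitor), giving > 50000 nM. Compound 1 `Cc1ccc2c(c1)C1(C(=O)N2C)C(C#N)=C(N)Oc2cc3oc(-c4ccccc4)cc(=O)c3c(O)c21` gives 10200 nM in this assay. Compound 2 `CN1C(=O)C2(C(C#N)=C(N)Oc3cc4oc(-c5ccccc5)cc(=O)c4c(O)c32)c2cccc(Cl)c21` likewise sits at a limit, with > 50000 nM in this assay. Compound 3 thus belongs to the limit of > 50000 nM in this assay, at which 2 of the 3 values shown sit. Compound 4 `N#CC1=C(N)Oc2cc3oc(-c4ccccc4)cc(=O)c3c(O)c2C12C(=O)N(Cc1ccccc1)c1ccc(F)cc12` differs from compound 3 by fluoro in place of methyl on an aromatic carbon. For the measured compounds named here, the single measured step, an at least 4.9-fold higher number from compound 1 to compound 3 (0.69 log units; beyond the scatter), concerns the group on the ring nitrogen, not the aromatic carbon, so no measured step bears on fluoro in place of methyl. Compound 2 carries chloro on an aromatic carbon and also sits at a limit, but no step to it is shown. Compound 4 is therefore expected to remain near the limit, the step that the limit leaves unreadable from compound 3 to compound 4 being small. The estimate for compound 4 in this assay is 60000 nM, ranging from 20000 nM to 200000 nM.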

Compound 4, half-maximal inhibitory concentration: > 50000 nM
Compound 4 was reported as a limit; the forecaster's own chance of this, stated with the estimate: 75%; the middle value lies beyond the limit too.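

Compound 3 and compound 4 both stand at a limit in this assay, and no step from methyl to fluoro can be read between them: the limit of > 50000 nM in this assay, at which 3 of the 4 values shown sit.

The compounds shown leave open whether fluoro in place of methyl on this aromatic carbon changes activity at all.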